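The source may hold more compounds than are shown below. What is called first, only, known or untested is meant among the compounds shown, and "the series" means these compounds.

Working notes on the series built on the core of compound 1 (`Cc1cn([C@@H]2O[C@H](CO[Si](C)(C)C(C)(C)C)[C@@]3(OS(=O)(=O)C=C3N)[C@H]2O[Si](C)(C)C(C)(C)C)c(=O)n(C(=O)C2CC2)c1=O`). In an ADME assay on CCRF-CEM cells (Homo sapiens) for cytotoxicity, with a stated time of 4 days (on this read-out higher numbers stand for lower toxicity in this test and lower numbers for higher toxicity in this test), compound 1 gives 11000 nM. In this assay, compound 2 (`CSC(=O)CCCC(=O)n1c(=O)c(C)cn([C@@H]2O[C@H](CO[Si](C)(C)C(C)(C)C)[C@@]3(OS(=O)(=O)C=C3N)[C@H]2O[Si](C)(C)C(C)(C)C)c1=O`) gives 9900 nM, so the two numbers lie within the scatter of each other and cannot be ranked. Compound 3 (`Cc1cn([C@@H]2O[C@H](CO[Si](C)(C)C(C)(C)C)[C@@]3(OS(=O)(=O)C=C3N)[C@H]2O[Si](C)(C)C(C)(C)C)c(=O)n(C(=O)CCCC(=O)OC(C)(C)C)c1=O`) has not yet been measured. Its difference from compound 2 is tert-butoxy in place of methylsulfanyl on a carbonyl carbon, which turns (methylsulfanyl)carbonyl into tert-butoxycarbonyl. Within the data shown here, only one measured step bears on this change: a 1.1-fold lower number from compound 1 to compound 2 (0.05 log units; within the scatter). That step also altered the group on a carbonyl carbon, and the number did not move beyond the scatter. Among the measured compounds shown here, it is a single step, and no measured compound carries tert-butoxy, so the evidence is thin. No shift beyond the scatter is expected, in either direction. The expected step is a 1.0-fold higher number from compound 2 to compound 3 (0.00 log units; within the scatter). For compound 3, the estimated value is 10000 nM, with an expected range of 5000 nM to 21000 nM.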

Compound 3, half-maximal cytotoxic concentration: 11000 nM
For compound 3 the middle estimate is 1.1-fold (0.04 log units) below the measured one, and the stated range covers the measured number.
By their numbers in this assay, from the lowest: compounds 2, 1 and 3 (each within the scatter of the next).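

On the carbonyl carbon whose other neighbour is a saturated chain carbon, tert-butoxy with its 5 heavy atoms replaces methylsulfanyl with its 2, and this assay shows a 1.1-fold higher number from compound 2 to compound 3 (0.05 log units; within the scatter) as the reading for that exchange, so this change of end group on the chain leaves the cytotoxicity number within the scatter. Replacing cyclopropyl with 3-(tert-butoxycarbonyl)propyl gives no change at the digits printed from compound 1 to compound 3 (within the scatter) and adds a second chain-bearing comparison with the cyclopropyl compound, so cyclopropyl, 3-((methylsulfanyl)carbonyl)propyl and 3-(tert-butoxycarbonyl)propyl on this carbonyl carbon cannot be ranked in this read-out. No supporting data bear on why the number stays put.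

The compounds shown leave open whether a free carboxylic acid or an amine at the end of the chain, or a longer chain, would move the number beyond the scatter. All three share the core of compound 1, so whether these exchanges read the same way on a core lacking its silyl ether groups also remains unanswered.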